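The compounds below may be only part of what the source reports. "The series", "measured", "known", "first", "only" and "open" are said of these compounds alone.

Three compounds share one core and differ only in the group on the outer aromatic ring. Compound 1 `O=C(OC1(C(=O)Nc2ccc([N+](=O)[O-])cc2)CCCCC1)c1ccc(C(F)(F)F)cc1` carries a trifluoromethyl group and gives 27.1 nM in a functional assay on MCF7 cells (Homo sapiens) for inhibition, read by MTT assay, with a stated time of 72 h; on this read-out higher numbers stand for weaker inhibition and lower numbers for stronger inhibition. Compound 2 `Cc1ccc(C(=O)OC2(C(=O)Nc3ccc([N+](=O)[O-])cc3)CCCCC2)cc1` carries methyl instead and gives 9.8 nM; compound 3 `COc1ccc(C(=O)OC2(C(=O)Nc3ccc([N+](=O)[O-])cc3)CCCCC2)cc1` carries methoxy and gives 41.2 nM. Compound 2 thus has the lowest number of the three, since both the step of a 2.8-fold lower number from compound 1 to compound 2 (0.44 log units; beyond the scatter) and the step of a 4.2-fold higher number from compound 2 to compound 3 (0.62 log units; beyond the scatter) lie beyond the scatter. Compound 4 `O=C(OC1(C(=O)Nc2ccc([N+](=O)[O-])cc2)CCCCC1)c1ccc([N+](=O)[O-])cc1` arises from compound 2 by nitro in place of methyl on an aromatic carbon. Among the compounds with values here, no measured compound carries a nitro group at that place, but moving away from methyl, whether toward trifluoromethyl (the step of a 2.8-fold lower number from compound 1 to compound 2 (0.44 log units; beyond the scatter) seen in reverse) or toward methoxy (a 4.2-fold higher number from compound 2 to compound 3 (0.62 log units; beyond the scatter)), raised the number modestly each time. A modest rise is therefore expected, a 3.1-fold higher number from compound 2 to compound 4 (0.49 log units; beyond the scatter). Compound 4 is estimated at 30 nM, with a range of 10 nM to 90 nM.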

Compound 4, half-maximal inhibitory concentration: 8.7 nM
For compound 4 the middle estimate is 3.4-fold (0.54 log units) above the measured one, outside the stated range (below it).
By their numbers in this assay, from the lowest: compounds 4 and 2 (each within the scatter of the next); then compounds 1 and 3 (each within the scatter of the next).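

In this assay the step of a 1.1-fold lower number from compound 2 to compound 4 (0.05 log units; within the scatter) shows that leaving methyl at this place on the ring need not raise the number, unlike the moves to trifluoromethyl and methoxy. Nitro also stands clear of both those groups, through the steps of a 4.7-fold lower number from compound 3 to compound 4 (0.68 log units; beyond the scatter) and a 3.1-fold lower number from compound 1 to compound 4 (0.49 log units; beyond the scatter) in this set. Nothing available here explains why these groups fall as they do. The compounds shown leave open what an amine, a carboxylic acid or a longer chain would give at this place on the ring.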